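Pyridin-4-yl in place of pyridin-2-yl on an amine nitrogen

The source may hold more compounds than are shown below. What is called first, only, known or untested is meant among the compounds shown, and "the series" means these compounds.

Measured so far in a physicochemical assay for lipophilicity, read by HPLC; on this read-out higher numbers stand for higher lipophilicity and lower numbers for lower lipophilicity
Compound 1 `CC(=O)NC[C@H]1CN(c2ccc(OC[C@@H](O)CNc3ccccc3)c(F)c2)C(=O)O1` gives 1.42
Compound 2 `CC(=O)NC[C@H]1CN(c2ccc(OC[C@H](O)CNc3ccccc3)c(F)c2)C(=O)O1` gives 0.59
Compound 3 `CC(=O)NC[C@H]1CN(c2ccc(OC[C@H](O)CNc3ccccn3)c(F)c2)C(=O)O1` gives 1.6

The numbers show a number 0.18 log units higher from compound 1 to compound 3 (within the scatter) and a number 1.01 log units higher from compound 2 to compound 3 (beyond the scatter) as the two steps that place the pyridin-2-yl compound. Compound 4 `CC(=O)NC[C@H]1CN(c2ccc(OC[C@H](O)CNc3ccncc3)c(F)c2)C(=O)O1` carries pyridin-4-yl in place of pyridin-2-yl on an amine nitrogen and is otherwise unchanged. For the measured compounds named here, the nearest precedent is the ring swap on that same nitrogen, a number 1.01 log units higher from compound 2 to compound 3 (beyond the scatter) which shows that such a swap can move this number a long way. Going by the values given here, no measured step shows the direction for this change, but compound 3 at 1.6 already shares the upper end of the values, so a fall is the likelier outcome. An estimated a number 0.70 log units lower from compound 3 to compound 4 (beyond the scatter) is therefore expected in this assay with a wide margin. Compound 4 is expected at 0.9 within a range from 0.2 to 1.6 on this estimate.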

Compound 4, partition coefficient: 0.02
For compound 4 the middle estimate is 0.88 log units above the measured one; measured number below the stated range.
By their numbers in this assay, from the lowest: compound 4; then compound 2; then compounds 1 and 3 (each within the scatter of the next).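

In this assay, pyridin-4-yl in place of pyridin-2-yl on an amine nitrogen gives a number 1.58 log units lower from compound 3 to compound 4 (beyond the scatter), although the two compounds have the same atoms, joined differently. Starting from phenyl, the two pyridine rings part ways, with a number 0.57 log units lower from compound 2 to compound 4 (beyond the scatter) but a number 1.01 log units higher from compound 2 to compound 3 (beyond the scatter), so replacing phenyl with a pyridine ring has no single direction at this position. Nothing measured here explains this.

Across both a change of ring and a change of configuration there is a number 1.40 log units lower from compound 1 to compound 4 (beyond the scatter), so that step cannot be read. Pyridin-3-yl on the same nitrogen remains open, as does pyridin-4-yl with the configuration of compound 1.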